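Swapping the methoxyphenyl of compound 3 for a nitrophenyl

The source may report more compounds than this note shows. Statements on the series, on what has been measured and on what is new or still open speak of the compounds shown alone.

Of the compounds shown here, three sharing one core have been tested in a functional assay on ECa-109 cells (Homo sapiens) for inhibition, read by MTT assay, with a stated time of 72 h; on this read-out lower numbers stand for stronger inhibition and higher numbers for weaker inhibition. Compound 1 `COc1ccc(Nc2nc(SCc3cn(Cc4ccccc4Cl)nn3)nc(-c3ccccc3)c2C#N)cc1` gives 7960 nM, compound 2 `N#Cc1c(Nc2ccc(Cl)cc2)nc(SCc2cn(Cc3ccccc3Cl)nn2)nc1-c1ccccc1` gives 1420 nM, and compound 3 `COc1ccccc1Nc1nc(SCc2cn(Cc3ccccc3Cl)nn2)nc(-c2ccccc2)c1C#N` gives 9670 nM. Compound 3 thus has the highest of the three numbers: it sits a 1.2-fold higher number from compound 1 to compound 3 (0.08 log units; within the scatter) beside compound 1, while the larger step is a 6.8-fold higher number from compound 2 to compound 3 (0.83 log units; beyond the scatter).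

Compound 4 `N#Cc1c(Nc2cccc([N+](=O)[O-])c2)nc(SCc2cn(Cc3ccccc3Cl)nn2)nc1-c1ccccc1` differs from compound 3 in one place: 3-nitrophenyl in place of 2-methoxyphenyl on a nitrogen on an aromatic ring. Among the compounds with values here, no measured step involves a nitrophenyl, so the nearest guides are a 5.6-fold lower number from compound 1 to compound 2 (0.75 log units; beyond the scatter) and a 6.8-fold higher number from compound 2 to compound 3 (0.83 log units; beyond the scatter), which show that replacing a methoxyphenyl on that nitrogen by another substituted phenyl can move the number by a modest amount in either direction. Because the only measured departure from methoxy, a 5.6-fold lower number from compound 1 to compound 2 (0.75 log units; beyond the scatter), lowered the number, a modest decrease is expected for compound 4, of about a 3.2-fold lower number from compound 3 to compound 4 (0.51 log units; beyond the scatter). Compound 4 is therefore estimated at 3000 nM in this assay, with a range from 900 nM to 10000 nM.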

Compound 4, half-maximal inhibitory concentration: > 64000 nM
Compound 4 gave a limit, no number (the forecaster's own chance of this, stated with the estimate: 5%); middle value at least 21-fold (1.32 log units) from the limit.
By their numbers in this assay, from the lowest: compound 2; then compounds 1 and 3 (each within the scatter of the next). At a limit, above all of these: compound 4.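

Compound 4 gave a limit and not a number: the limit of > 64000 nM in this assay, at which 1 of the 4 values shown sits. On the nitrogen on an aromatic ring, the aryl group can therefore do more than shift the number modestly, as the change to 3-nitrophenyl gives an at least 6.6-fold higher number from compound 3 to compound 4 (0.82 log units; beyond the scatter), an at least 8.0-fold higher number from compound 1 to compound 4 (0.90 log units; beyond the scatter) and an at least 45-fold higher number from compound 2 to compound 4 (1.65 log units; beyond the scatter). Leaving methoxyphenyl does not always lower the number, since the 4-chlorophenyl of compound 2 and the 3-nitrophenyl of compound 4 lie on opposite sides of compounds 1 and 3.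

Going by these compounds, how far the true value of compound 4 lies past its limit remains open. Compounds 2 and 4 differ in both the group and its place on the phenyl ring, so a 4-nitrophenyl or a 3-chlorophenyl would be needed to separate the two, and a 4-aminophenyl would show whether the nitro group itself matters.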